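From diethylamino to 1H-imidazol-1-yl in a small series

A few compounds are considered here, and "the series" means these few. Any claim that something is new, unique, unknown or untested is made for them only; others in the source may bear on it.

Among the compounds with values here, only two measured compounds anchor this small series. Compound 1 `CCN(CC)Cc1cccc2c(=O)cc(-c3ccc([N+](=O)[O-])cc3)oc12` has no usable number in a functional assay on SMMC-7721 cells (Homo sapiens) for cytotoxicity, read by MTT assay, with a stated time of 48 h (on this read-out lower numbers stand for stronger inhibition and higher numbers for weaker inhibition), where its entry reads "not determined" (no result reported). In this assay, within the data shown here, compound 2 `CCN(CC)Cc1cc(Cl)cc2c(=O)cc(-c3ccc([N+](=O)[O-])cc3)oc12` gives 2990 nM, the only number available, so it cannot yet be ranked as strong or weak against any other compound. Compound 3 `O=c1cc(-c2ccc([N+](=O)[O-])cc2)oc2c(Cn3ccnc3)cc(Cl)cc12` keeps the core of compound 2 and carries a single change: 1H-imidazol-1-yl in place of diethylamino on a saturated chain carbon bound to an aromatic carbon. Put simply, 1H-imidazol-1-yl stands in place of diethylamino on a saturated chain carbon bound to an aromatic carbon. Among the measured compounds shown here, no measured pair shows what such a swap does, so any expectation is loose. A modest loss of inhibition seems likeliest, though a step within the usual scatter would be no surprise. The expected change is a 1.3-fold higher number from compound 2 to compound 3 (0.13 log units; within the scatter). For compound 3 the estimated value in this assay is 4000 nM, with an expected range from 1200 nM to 15000 nM.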

Compound 3, half-maximal inhibitory concentration: 1200 nM
The estimate for compound 3 lay 3.3-fold (0.52 log units) above the measured number; measured number inside the range.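

In this assay, the change at this position gives a 2.5-fold lower number from compound 2 to compound 3 (0.40 log units; beyond the scatter), which shows that the number does respond to the group carried on this saturated chain carbon. Both groups have 5 heavy atoms, so this step swaps diethylamino, which has no ring, for a five-membered aromatic ring with 2 hetero atoms, while the count of heavy atoms stays the same. No measurement shown here explains the step.

This is a single pair, so it sets no general pattern for the series. From the compounds shown here alone, it remains open whether morpholin-4-yl, a saturated ring, or 1H-pyrrol-1-yl, an aromatic five-membered ring with one nitrogen, would give a lower or a higher number in the same place.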